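The source may hold more compounds than are shown below. What is called first, only, known or untested is meant among the compounds shown, and "the series" means these compounds.

Measured in a functional assay on CWR22R cells (Homo sapiens) for antiproliferative activity, read by propidium iodide staining, with a stated time of 96 h; on this read-out lower numbers stand for stronger inhibition and higher numbers for weaker inhibition:
- Compound 1 `CC(O)(CSc1ccc(F)cc1)C(=O)Nc1cccc(S(F)(F)(F)(F)F)c1`: 30200 nM
- Compound 2 `CC(O)(CSc1ccccc1C(F)(F)F)C(=O)Nc1cccc(S(F)(F)(F)(F)F)c1`: 13200 nM

Going by the values given here, compound 2, at 13200 nM, holds the lowest number of the pair, and compound 1 is its only neighbour. Compound 3 `CC(O)(CSc1ccccc1OC(F)(F)F)C(=O)Nc1cccc(S(F)(F)(F)(F)F)c1` differs from compound 2 by one change: trifluoromethoxy in place of trifluoromethyl on an aromatic carbon. This puts trifluoromethoxy in place of trifluoromethyl on an aromatic carbon, ortho to a large group.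

Among the compounds with values here, only one measured step bears on this change: a 2.3-fold lower number from compound 1 to compound 2 (0.36 log units; beyond the scatter). It altered the same aromatic group, but it was modest and involved a different exchange, so no measurement tests this replacement directly. In this assay, no step beyond the scatter is therefore expected, and no direction can be favoured with confidence. The expected change is a 1.1-fold lower number from compound 2 to compound 3 (0.04 log units; within the scatter). For compound 3 the estimated value is 12000 nM, with an expected range from 5000 nM to 30000 nM.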

Compound 3, half-maximal inhibitory concentration: 13900 nM
For compound 3 the middle estimate is 1.2-fold (0.06 log units) below the measured one, and the stated range covers the measured number.
By their numbers in this assay, from the lowest: compounds 2 and 3 (each within the scatter of the next); then compound 1.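

In this assay the exchange of trifluoromethyl for trifluoromethoxy gives a 1.1-fold higher number from compound 2 to compound 3 (0.02 log units; within the scatter) and so leaves the number within the scatter, which shows that this place, on an aromatic carbon ortho to a large group, accepts the extra oxygen and its hydrogen-bond acceptor without a readable change in this read-out. Going by these compounds alone, the only earlier step replaced one whole substituted aromatic group with another, whereas this one isolates a single group at a single place, and the two values stand level with each other.

The compounds shown leave open whether an amine, a carboxylic acid or a longer chain at this place would hold the number or shift it, since both groups compared here are small and fluorinated. Nothing given here accounts for why the two groups read alike.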